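Removing one methyl from compound 3

The source may report more compounds than this note shows. Statements on the series, on what has been measured and on what is new or still open speak of the compounds shown alone.

Compound 1 `Cn1nc(-c2cccc(C(F)(F)F)c2)n(C)c1=S`: > 200 mg/kg
Compound 2 `CCn1c(-c2ccccc2)nn(C)c1=S`: 1.2 mg/kg
Compound 3 `Cc1ccc(-c2nn(C)c(=S)n2C)cc1`: 4.2 mg/kg

These values come from a functional assay on the whole organism with Mus musculus as the target; a lower number here means that less compound is needed, a higher number that more compound is needed for the effect. For compound 1, > 200 mg/kg is a limit of the assay and not a number. Of the two true numbers, compound 3 has the higher one, and its gap to compound 2 lies beyond the usual scatter. Compound 4 `Cn1nc(-c2ccccc2)n(C)c1=S` has hydrogen in place of methyl on an aromatic carbon. Among the measured compounds shown here, no measured pair shows this change alone. Compound 2 also carries hydrogen at that carbon and gives 1.2 mg/kg, though it differs elsewhere too. The expected change is a 1.7-fold lower number from compound 3 to compound 4 (0.23 log units; within the scatter), small, leaning towards a lower number and probably within the scatter. Compound 4 is estimated at 2.5 mg/kg, with an expected range from 0.8 mg/kg to 8 mg/kg.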

Compound 4, dose for half-maximal effect: 0.13 mg/kg
For compound 4 the middle estimate is 19-fold (1.28 log units) above the measured one; the measured number lies below the stated range.
By their numbers in this assay, from the lowest: compound 4; then compound 2; then compound 3. At a limit, above all of these: compound 1.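

Among the compounds shown here, a single methyl on the aromatic carbon matters far more than the earlier compounds showed, with a 32-fold lower number from compound 3 to compound 4 (1.51 log units; beyond the scatter). Hydrogen in place of methyl on a saturated chain carbon bound to an aromatic nitrogen also counts, giving a 9.2-fold lower number from compound 2 to compound 4 (0.97 log units; beyond the scatter). Hydrogen in place of trifluoromethyl on an aromatic carbon gives an at least 1500-fold lower number from compound 1 to compound 4 (3.18 log units; beyond the scatter), and the value of compound 1 is a limit, not a number: the limit of > 200 mg/kg in this assay, at which 1 of the 4 values shown sits.

As far as these compounds go, it remains open whether a chlorine or a methoxy group on that aromatic carbon would also raise the number, or whether this holds for methyl alone.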